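The source may hold more compounds than are shown below. What is called first, only, known or untested is meant among the compounds shown, and "the series" means these compounds.

Measured so far:
- compound 1 `O=C(/C=C/c1cccc(Cl)c1Cl)Nc1cc2c(Nc3ccc(F)c(Cl)c3)ncnc2cc1O[C@H]1CCOC1`: 30500 nM
- compound 2 `COc1cc(/C=C/C(=O)Nc2cc3c(Nc4ccc(F)c(Cl)c4)ncnc3cc2OC)cc(OC)c1`: "not determined" (no result reported)

The read-out is a functional assay on HeLa cells (Homo sapiens) for cytotoxicity, read by MTT assay, with a stated time of 72 h; on this read-out lower numbers stand for stronger inhibition and higher numbers for weaker inhibition. In this assay, going by the values given here, compound 1 gives 30500 nM, the only number here, so it stands alone with nothing to rank it against, and compound 2 carries no result at all. Compound 3 `COc1cc(/C=C/C(=O)Nc2cc3c(Nc4ccc(F)c(Cl)c4)ncnc3cc2O[C@H]2CCOC2)cc(OC)c1O` has not yet been measured. It differs from compound 1 in one place: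

4-hydroxy-3,5-dimethoxyphenyl in place of 2,3-dichlorophenyl on a double-bonded chain carbon bound to a double-bonded chain carbon

Both compounds keep the same core and the same double-bonded chain carrying the amide. Among the compounds with values here, no step between two measured compounds has been recorded, so there is no measured change of this kind to lean on, and the single weak number of compound 1 is the only anchor. A change of one ring substituent on the outer end of the chain, with the rest of the molecule untouched, is expected to move the number only modestly. The expected step is a 1.1-fold higher number from compound 1 to compound 3 (0.06 log units; within the scatter), which is judged small and likely to stay within the usual scatter. Compound 3 is therefore estimated at 35000 nM in this assay, with a range from 10000 nM to 100000 nM.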

Compound 3, half-maximal inhibitory concentration: 27400 nM
Estimate against measurement, compound 3: 1.3-fold (0.11 log units) above; the measured number falls inside the stated range.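

In this assay, putting 4-hydroxy-3,5-dimethoxyphenyl in place of 2,3-dichlorophenyl gives a 1.1-fold lower number from compound 1 to compound 3 (0.05 log units; within the scatter) and so leaves the two compounds indistinguishable. Going by these compounds alone, this is the first measured step at this place, on a double-bonded chain carbon bound to a double-bonded chain carbon, and it shows that two quite different rings can give readings that cannot be told apart: one carries two chlorine atoms and has 0 hydrogen-bond donors and 0 hydrogen-bond acceptors, while the other carries three oxygen atoms and has 1 hydrogen-bond donor and 3 hydrogen-bond acceptors. Nothing measured here offers a reason for this result.

The compounds shown leave open whether any group at this place could move the number beyond the usual scatter, for example a ring bearing an amine or a carboxylic acid, or a longer chain in place of the ring. Since compound 2 carries no result, they also leave open how a change elsewhere on the shared core would affect the reading.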